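The compounds below may be only part of what the source reports. "The series", "measured", "known", "first", "only" and "open" are said of these compounds alone.

Of the compounds shown here, three have so far been tested in an assay on isolated protein for displacement of a labelled ligand from metabotropic glutamate receptor 5 (Homo sapiens), with a stated time of 60 min, tested at 1 uM; on this read-out lower numbers stand for less inhibition and higher numbers for more inhibition at the one concentration tested (going by the name of the read-out). Compound 1, `COc1ccc(S(=O)(=O)c2cnc3cc(Cl)ccc3c2N2CCC(C)CC2)cc1Cl`, gives 93% in this assay. Compound 3, `CC1CCN(c2c(S(=O)(=O)c3ccc(F)c(Cl)c3)cnc3cc(F)ccc23)CC1`, gives 94%, a number that sits within the usual scatter of the reading for compound 1, so the two cannot be told apart. Compound 2, `O=S(=O)(c1ccc(F)cc1)c1cnc2cc(Cl)ccc2c1N1CCC(CO)CC1`, gives 75%, which lies well below compound 1, beyond the scatter. Compound 1 therefore stands second highest of the three numbers, close to compound 3 and clearly apart from compound 2.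

Compound 4, `CC1CCN(c2c(S(=O)(=O)c3cc(Cl)cc(Cl)c3)cnc3cc(Cl)ccc23)CC1`, has not yet been measured in this assay. It differs from compound 1 in one place: 3,5-dichlorophenyl in place of 3-chloro-4-methoxyphenyl on a sulfonyl sulfur. The ring that carries the sulfonyl sulfur keeps a single six-membered aromatic ring but loses its one hydrogen-bond acceptor and gains a second chlorine.

Going by the values given here, no pair of measured compounds differs in exactly this way, so the size of the step is open. Because compound 3 gives 94% with a chlorine-bearing ring on the sulfonyl sulfur, a high reading for compound 4 is expected. The step from compound 1 to compound 4 is estimated at a number 5 percentage points lower from compound 1 to compound 4 (within the scatter), a change not clearly beyond the scatter. Compound 4 is expected to give about 88%, most likely between 70% and 98%.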

Compound 4, a percentage reported as inhibition, at one concentration (the size of the read-out at that concentration, not a potency): 93%
Beside the measured number, compound 4's estimate is 5 percentage points below it; measured number inside the range.
By their numbers in this assay, from the lowest: compound 2; then compounds 1, 4 and 3 (each within the scatter of the next).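

In this assay, going by these compounds alone, putting 3,5-dichlorophenyl in place of 3-chloro-4-methoxyphenyl on a sulfonyl sulfur gives no change at the digits printed from compound 1 to compound 4 (within the scatter), and this is the first step in the set that changes only one place. For this pair, the ring on the sulfonyl sulfur can lose its one hydrogen-bond acceptor and gain a second chlorine while the reading stays high, so that acceptor is not required for a high reading at the one concentration tested. No measurement at hand accounts for this result, so it stands as an observation only.

Both compounds sit so high on this percentage scale that a reading at a single concentration could hide a real difference in potency, which only a series of concentrations could reveal. On these data alone, it also remains open whether a high reading would survive a larger change at this position, such as a propyl chain in place of the aromatic ring, or an amine or a carboxylic acid carried on that ring.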